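Extending an Anilide Into a Naphthyl Amide

This account rests on a few compounds, and the source may have more. Where it says the series, first, only, none or still open, it means among the compounds named here.

Compound 1: `N=C(N)Nc1cccc(C(=O)NCC(=O)N[C@@H](CC(=O)O)C(=O)Nc2ccccc2)c1`, 13 nM
Compound 2: `N=C(N)Nc1cccc(C(=O)NCC(=O)N[C@@H](CC(=O)O)C(=O)NC(c2ccccc2)c2ccccc2)c1`, 22 nM

Both compounds were tested in an assay on a protein complex for binding affinity to integrin alpha-5/beta-1 (Homo sapiens), read by ELISA, with a stated time of 1 h; a lower number here means a stronger inhibitor, a higher number a weaker inhibitor. Compound 1 gives 13 nM, the lowest of the two numbers. Compound 2 gives 22 nM, and the gap between the two lies within the usual scatter, so the pair cannot be ranked. For the measured compounds named here, no step between measured compounds differing in a single place has been recorded, and compound 2 shows only that a different group on the same amide nitrogen gives a similar value.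

Compound 3, `N=C(N)Nc1cccc(C(=O)NCC(=O)N[C@@H](CC(=O)O)C(=O)Nc2cccc3ccccc23)c1`, has not yet been measured. It differs from compound 1 in one place: naphthalen-1-yl in place of phenyl on an amide-type nitrogen. Going by the values given here, with compound 2 at 22 nM as the only guide, a step beyond the scatter in this assay is not expected in either direction. The expected step from compound 1 to compound 3 is a 1.2-fold higher number from compound 1 to compound 3 (0.06 log units; within the scatter). Compound 3 is therefore estimated at 15 nM, within a range from 5 nM to 50 nM.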

Compound 3, half-maximal inhibitory concentration: 22 nM
Compound 3: middle estimate off by 1.5-fold (0.17 log units), on the low side; the measured number falls inside the stated range.
By their numbers in this assay, from the lowest: compounds 1, 2 and 3 (each within the scatter of the next).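

Compound 1 and compound 3 differ in one place only, so this change can be read directly: in this assay, naphthalen-1-yl in place of phenyl on an amide-type nitrogen gives a 1.7-fold higher number from compound 1 to compound 3 (0.23 log units; within the scatter). The two compounds cannot be ranked, which means that going from one aromatic ring to two at this place, with 10 heavy atoms instead of 6, produces no step beyond the scatter. Nothing measured here gives a reason for this result.

All the groups shown on this nitrogen are made of carbon and hydrogen only, so it remains open whether a ring carrying an amine or a carboxylic acid would give a similar value. As far as these compounds go, it is also open whether a longer chain holding the phenyl ring on this nitrogen would do so.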